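Fluoro Added to the Benzamido Group of Compound 2

This account rests on a few compounds, and the source may have more. Where it says the series, first, only, none or still open, it means among the compounds named here.

Measured so far in a functional assay on Ramos cells (Homo sapiens) for antiproliferative activity, read by CCK-8 assay, with a stated time of 72 h, tested at 40 uM; on this read-out higher numbers stand for more inhibition at the one concentration tested (going by the name of the read-out) and lower numbers for less inhibition:
compound 1, `CCOC(=O)c1sc(-c2cccc(NC(=O)c3ccc(C(F)(F)F)cc3)c2)nc1Nc1ccc(N2CCN(C)CC2)cc1`, gives 18.4%;
compound 2, `CCOC(=O)c1sc(-c2cccc(NC(=O)c3ccccc3)c2)nc1Nc1ccc(N2CCN(C)CC2)cc1`, gives 77.1%.

Compound 2 stands at the higher of the two numbers. Among the compounds with values here, only one step links the two compounds: a number 58.7 percentage points higher from compound 1 to compound 2 (beyond the scatter). That step took out a trifluoromethyl group on an aromatic carbon and put hydrogen in its place, and the inhibition rose sharply.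

Compound 3, `CCOC(=O)c1sc(-c2cccc(NC(=O)c3cccc(F)c3)c2)nc1Nc1ccc(N2CCN(C)CC2)cc1`, goes the other way, putting a fluorine-containing group back onto the same benzamido part: fluoro in place of hydrogen on an aromatic carbon. Within the data shown here, only the step from compound 1 to compound 2 bears on this, and it was large. The new change is smaller in size than a trifluoromethyl group and sits at a different place on the ring, so a drop in this assay is expected, but a less severe one. The expected step is a number 19.1 percentage points lower from compound 2 to compound 3 (beyond the scatter), downward. Compound 3 is estimated at 58%, within a range from 30% to 82%.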

Compound 3, a percentage reported as inhibition, at one concentration (the size of the read-out at that concentration, not a potency): 85.2%
Compound 3: the middle estimate sits 27.2 percentage points below what was measured; the measured number lies above the stated range.
By their numbers in this assay, from the lowest: compound 1; then compounds 2 and 3 (each within the scatter of the next).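

Adding fluoro to the benzamido ring of compound 2, on an aromatic carbon meta to a large group, gives a number 8.1 percentage points higher from compound 2 to compound 3 (within the scatter) in this assay, so the two compounds cannot be told apart on this read-out and this position accepts a fluoro group. The comparison with the trifluoromethyl compound gives a number 66.8 percentage points higher from compound 1 to compound 3 (beyond the scatter) and shows that a fluorine-bearing benzamido group does not by itself go with the low number of compound 1, although this step changes both the group and its place on the ring. No measurement of any property of these groups is at hand to account for either step.

From the compounds shown here alone, it remains open whether the low number of compound 1 goes with the trifluoromethyl group itself or with its place, and a 3-(trifluoromethyl)phenyl or a 4-fluorophenyl group would pull those two apart. How a different kind of group on this same carbon, such as an amine or a carboxylic acid, would read is also open, and a single tested concentration gives no potency for any of these compounds.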